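The source may hold more compounds than are shown below. What is called first, only, known or untested is meant among the compounds shown, and "the series" means these compounds.

Working notes on the series.

Compound 1 `Fc1ccc(Sc2ncnc3[nH]cnc23)cc1` is the unsubstituted parent; in an assay on isolated protein for inhibition of Rho-associated protein kinase 1 (Homo sapiens), tested at 30 uM (on this read-out lower numbers stand for less inhibition and higher numbers for more inhibition at the one concentration tested (going by the name of the read-out)), compound 1 gives 37%. Compound 2 `Cn1cnc2c(Sc3ccc(F)cc3)ncnc21` carries methyl in place of hydrogen on an aromatic nitrogen, and in this assay compound 2 gives 6%. For the measured compounds named here, the single measured step is a number 31 percentage points lower from compound 1 to compound 2 (beyond the scatter), so compound 2 stands lowest of the two numbers recorded so far, with compound 1 as its only and nearest neighbour.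

Compound 3 `Cn1c(-c2ccccc2)nc2c(Sc3ccc(F)cc3)ncnc21` is the next member to be tested. It differs from compound 2 by phenyl in place of hydrogen on an aromatic carbon. Going by the values given here, no measured step touches this position or this kind of group: the one step known, methyl in place of hydrogen on an aromatic nitrogen, concerns a different place and a different group, and its size gives no guide to what a phenyl on the aromatic carbon will do. Starting from the low number of compound 2, the expectation for compound 3 in this assay is therefore no step beyond the scatter, a number 2 percentage points higher from compound 2 to compound 3 (within the scatter). The estimate for compound 3 is 8%, with a range from 0% to 25%.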

Compound 3, a percentage reported as inhibition, at one concentration (the size of the read-out at that concentration, not a potency): 9%
Compound 3: the middle estimate sits 1 percentage points below what was measured, within the range that was stated.
By their numbers in this assay, from the lowest: compounds 2 and 3 (each within the scatter of the next); then compound 1.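

In this assay, for the compounds shown here, phenyl in place of hydrogen on an aromatic carbon gives a number 3 percentage points higher from compound 2 to compound 3 (within the scatter), the first reading at this carbon of the five-membered aromatic ring, between two ring nitrogen atoms and next to the ring atom that bears a methyl group. On the methylated core, this position therefore takes a whole phenyl ring without a change that can be told from the scatter, and the group adds no inhibition that can be read at the one concentration tested. Since both numbers lie low on this read-out, the step says little about whether a loss would show here, and no measurement at hand bears on the reason for the result.

Open, as far as these compounds go, is whether phenyl at this carbon would read the same with hydrogen rather than methyl on the aromatic nitrogen, on the core of compound 1 at 37%, where the number starts higher. Also open is what an amine, a carboxylic acid or a longer alkyl chain would give at this carbon, as phenyl is the only group shown there.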